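A few compounds are considered here, and "the series" means these few. Any claim that something is new, unique, unknown or untested is made for them only; others in the source may bear on it.

Measured so far in a physicochemical assay for solubility, in phosphate buffer; on this read-out lower numbers stand for lower solubility and higher numbers for higher solubility:
compound 1 `COc1ncnc2c1ncn2[C@@H]1O[C@H](COC(=O)C(C)(C)C)[C@@H](OC(=O)C(C)(C)C)[C@@H]1OC(=O)C(C)(C)C`: 14000 nM
compound 2 `COc1ncnc2c1ncn2[C@@H]1O[C@H](CO)[C@@H](OC(=O)C(C)(C)C)[C@@H]1OC(=O)C(C)(C)C`: 640000 nM

Going by the values given here, compound 1 gives the lower of the two numbers, and compound 2 is its only neighbour. The unmeasured compound 3 `COc1ncnc2c1ncn2[C@@H]1O[C@H](COC(=O)C(C)(C)C)[C@@H](O)[C@@H]1OC(=O)C(C)(C)C` differs from compound 1 by hydrogen in place of (tert-butyl)carbonyl on an oxygen on a saturated carbon. Among the compounds with values here, the one measured step that bears on this is the same kind of removal, a 46-fold higher number from compound 1 to compound 2 (1.66 log units; beyond the scatter), which was large. A step of similar kind and direction is therefore expected, and compound 3 is estimated at 400000 nM, in the range 100000 nM to 1600000 nM, which would mean a 29-fold higher number from compound 1 to compound 3 (1.46 log units; beyond the scatter).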

Compound 3, solubility: 1350000 nM
Beside the measured number, compound 3's estimate is 3.4-fold (0.53 log units) below it; the range from low to high includes it.
By their numbers in this assay, from the lowest: compound 1; then compound 2; then compound 3.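

At the oxygen on a saturated carbon whose other neighbours are saturated ring carbon, hydrogen in place of (tert-butyl)carbonyl gives, in this assay, a 96-fold higher number from compound 1 to compound 3 (1.98 log units; beyond the scatter). The large rise seen earlier, a 46-fold higher number from compound 1 to compound 2 (1.66 log units; beyond the scatter), is therefore not confined to one oxygen of compound 1: the same exchange at two different oxygens gives a large rise beyond the scatter. No evidence is available on what lies behind the rise at this position.

Still open, from the compounds shown here alone, is whether an acetyl group, a longer acyl chain or an amine on this oxygen would shift the number in the same direction. Also open, going by these compounds, is what the same exchange does at the remaining oxygen bearing (tert-butyl)carbonyl.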